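Dropping a Second Methoxy from a Chalcone-Linked Quinoline

The compounds below may be only part of what the source reports. "The series", "measured", "known", "first", "only" and "open" are said of these compounds alone.

The measured compounds:
- compound 1 `COc1cc(/C=C/C(=O)c2ccc(OCC(O)CNCCNc3ccnc4cc(Cl)ccc34)cc2)cc(OC)c1OC`: 1910 nM
- compound 2 `COc1ccc(/C=C/C(=O)c2ccc(OCC(O)CNCCNc3ccnc4cc(Cl)ccc34)cc2)cc1OC`: 10200 nM
- compound 3 `O=C(COc1ccccc1C(=O)/C=C/c1ccc(Cl)cc1)NCCNc1ccnc2cc(Cl)ccc12`: 4980 nM

All three were tested in an ADME assay on Vero cells (Chlorocebus sabaeus) for cytotoxicity, read by MTT assay, with a stated time of 72 h; on this read-out higher numbers stand for lower toxicity in this test and lower numbers for higher toxicity in this test. Compound 2 gives the highest number of the three in this assay; compound 3 comes nearest with a lower number that lies beyond the scatter, and compound 1 is furthest away with a lower number still, also beyond the scatter.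

The step to consider leads from compound 2 to the unmeasured compound 4 `COc1ccc(/C=C/C(=O)c2ccc(OCC(O)CNCCNc3ccnc4cc(Cl)ccc34)cc2)cc1`. The change is hydrogen in place of methoxy on an aromatic carbon.

Among the compounds with values here, one measured step bears on this: the same kind of change, hydrogen in place of methoxy on an aromatic carbon, gave a 5.3-fold higher number from compound 1 to compound 2 (0.73 log units; beyond the scatter). That step was modest and went towards a higher number in this assay. A single precedent is a thin basis, so a smaller move in the same direction is expected rather than a repeat of the full size.

For compound 4 the expected step is a 1.8-fold higher number from compound 2 to compound 4 (0.25 log units; within the scatter). The estimate for compound 4 in this assay is 18000 nM, within a range from 6000 nM to 50000 nM.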

Compound 4, half-maximal cytotoxic concentration: 8030 nM
Estimate against measurement, compound 4: 2.2-fold (0.35 log units) above; the measured number falls inside the stated range.
By their numbers in this assay, from the lowest: compound 1; then compounds 3, 4 and 2 (each within the scatter of the next, the first and the last beyond it).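

In this assay, replacing a methoxy group with hydrogen no longer has a readable effect at this position, ortho to a methoxy group: the step gives a 1.3-fold lower number from compound 2 to compound 4 (0.10 log units; within the scatter) and so stays within the scatter. The earlier step of the same kind, a 5.3-fold higher number from compound 1 to compound 2 (0.73 log units; beyond the scatter), lay beyond the scatter, which shows that one result for this type of change does not hold at every carbon of the ring. Taken as a whole, the move from 3,4,5-trimethoxyphenyl to 4-methoxyphenyl gives a 4.2-fold higher number from compound 1 to compound 4 (0.62 log units; beyond the scatter), a difference beyond the scatter, while compound 2 and compound 4 cannot be told apart in this test.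

As far as these compounds go, it remains open whether a hydroxyl group or an amine at this ring position, or hydrogen in place of the remaining methoxy group, would shift the number beyond the scatter. No measurement of any other property is available to explain why the two steps differ.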